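A few compounds are considered here, and "the series" means these few. Any claim that something is new, unique, unknown or untested is made for them only; others in the source may bear on it.

In an ADME assay on cells (Fibroblast, Homo sapiens) for antiproliferative activity, with a stated time of 48 h (on this read-out higher numbers stand for weaker inhibition and lower numbers for stronger inhibition), compound 1 `CCOC(=O)c1ccc(-c2ccc(N(CC)CC)nn2)cc1` gives 3000 nM. Compound 2 `CCOC(=O)c1ccc(-c2ccc(N(C)C)nn2)cc1` reaches only the limit of the test, > 25000 nM. Compound 3 `CCOC(=O)c1ccc(-c2ccc(OC(C)C)nn2)cc1` likewise stops at the limit, > 25000 nM. From the compounds shown here alone, the steps of an at least 8.3-fold higher number from compound 1 to compound 2 (0.92 log units; beyond the scatter) and an at least 8.3-fold higher number from compound 1 to compound 3 (0.92 log units; beyond the scatter) are both beyond the scatter, while a step that the two limits leave unreadable from compound 2 to compound 3 cannot be read, so compound 3 sits well away from compound 1 and its gap to compound 2 is unknown. Compound 4 `CCCCOc1ccc(-c2ccc(C(=O)OCC)cc2)nn1` differs from compound 3 in one place: butyl in place of isopropyl on an oxygen on an aromatic ring. Of the measured steps only an at least 8.3-fold higher number from compound 1 to compound 3 (0.92 log units; beyond the scatter) touches this position, and it swapped the whole group rather than the chain. A value at the limit is therefore expected again for compound 4, meaning a step that the limit leaves unreadable from compound 3 to compound 4. The estimate for compound 4 is 30000 nM, between 10000 nM and 100000 nM.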

Compound 4, half-maximal inhibitory concentration: > 25000 nM
Compound 4: a limit, no number (the forecaster's own chance of this, stated with the estimate: 70%); the middle value lies beyond the limit too.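

Changing isopropyl to butyl on the oxygen does not bring back a readable value: in this assay compound 4 gives > 25000 nM and that is a limit rather than a number. Putting butoxy in place of diethylamino gives an at least 8.3-fold higher number from compound 1 to compound 4 (0.92 log units; beyond the scatter) and so this longer chain on the oxygen does not close the gap to the amine of compound 1. The steps among compound 2, compound 3 and compound 4 cannot be read, as all three stop at the same limit: the limit of > 25000 nM in this assay, at which 3 of the 4 values shown sit.

Still open, from the compounds shown here alone, is whether a larger amine, such as dipropylamino, would give a real number here. Whether a still longer chain on the oxygen, such as hexyloxy, would do so is also unknown.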